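This account rests on a few compounds, and the source may have more. Where it says the series, first, only, none or still open, it means among the compounds named here.

Of the compounds shown here, two built on a shared core have been tested in an ADME assay on PC-3 cells (Homo sapiens) for cytotoxicity, read by WST assay, tested at 100 uM; a higher number here means more inhibition at the concentration tested (going by the name of the read-out), a lower number less inhibition. Compound 1 `O=C(Nc1cccc(Cc2ccccc2)c1)C1CCCN(C(=O)c2cc(C(F)(F)F)cc(C(F)(F)F)c2)C1` gives 0%. Compound 2 `O=C(Nc1ccc(Cl)nc1)C1CCCN(C(=O)c2cc(C(F)(F)F)cc(C(F)(F)F)c2)C1` gives 25%, the higher of the two numbers, and its gap to compound 1 lies beyond the scatter. Compound 3 `COc1cccc(NC(=O)C2CCCN(C(=O)c3cc(C(F)(F)F)cc(C(F)(F)F)c3)C2)c1` differs from compound 2 in one place: 3-methoxyphenyl in place of 6-chloropyridin-3-yl on an amide-type nitrogen. Among the compounds with values here, no measured pair shows this exact change. Compound 1 also carries an aromatic ring of carbon only on the amide-type nitrogen and gives 0%, which points downward. The step from compound 2 to compound 3 is therefore expected to be a number 15 percentage points lower from compound 2 to compound 3 (beyond the scatter). Compound 3 is estimated at 10%, within 0% to 30%.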

Compound 3, a percentage reported as inhibition, at one concentration (the size of the read-out at that concentration, not a potency): 0%
For compound 3 the middle estimate is 10 percentage points above the measured one, within the range that was stated.
By their numbers in this assay, from the lowest: compounds 1 and 3 (each within the scatter of the next); then compound 2.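

In this assay, within the data shown here, 3-methoxyphenyl in place of 6-chloropyridin-3-yl gives a number 25 percentage points lower from compound 2 to compound 3 (beyond the scatter) on this amide-type nitrogen, the first direct one-place reading of this change. Methoxy in place of benzyl on an aromatic carbon gives no change at the digits printed from compound 1 to compound 3 (within the scatter) in this series, so among these three compounds only the one carrying 6-chloropyridin-3-yl stands apart. No measurement at hand explains this difference.

Still open, going by these compounds, is whether the chlorine or the ring nitrogen of 6-chloropyridin-3-yl goes with the higher number. An unsubstituted pyridine ring or a chlorophenyl group on the same nitrogen would separate the two.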